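Removing one methyl from a pair at the limit

The source may report more compounds than this note shows. Statements on the series, on what has been measured and on what is new or still open speak of the compounds shown alone.

Compound 1 `CCCOc1c(OC)cc2oc(-c3ccccc3)cc(=O)c2c1O` gives > 100000 nM
Compound 2 `CCOc1cc2oc(-c3ccccc3)cc(=O)c2c(O)c1OCC` gives > 100000 nM

In a functional assay on KB cells (Homo sapiens) for inhibition, with a stated time of 72 h (on this read-out higher numbers stand for weaker inhibition and lower numbers for stronger inhibition), compound 2 gives > 100000 nM as its reading, which is a limit and not a number. Compound 1 gives > 100000 nM as its reading, again a limit. Compound 3 `CCOc1c(OC)cc2oc(-c3ccccc3)cc(=O)c2c1O` differs from compound 2 in one place (hydrogen in place of methyl on a saturated chain carbon bound to an oxygen on an aromatic ring), with hydrogen in place of methyl on a saturated chain carbon bound to an oxygen on an aromatic ring, so ethoxy becomes methoxy. Since compound 1 and compound 2 both sit at the limit of > 100000 nM in this assay, at which 2 of the 2 values shown sit, no step beyond the scatter is expected in either direction in this assay for this change. The estimated step runs a number no higher from compound 2 to compound 3 (the limit leaves the size open) and stays small. Compound 3 is expected near 100000 nM within an estimated range from 40000 nM to 200000 nM in this measurement.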

Compound 3, half-maximal inhibitory concentration: > 100000 nM
Compound 3 was reported as a limit; the forecaster's own chance of this, stated with the estimate: 80%; the middle value lies on the limit itself.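

No step can be read from compound 1 or compound 2 to compound 3, because all three readings in this assay are limits and not numbers: the limit of > 100000 nM in this assay, at which 3 of the 3 values shown sit.

The compounds shown leave open how strongly each one inhibits, and so whether ethoxy to methoxy makes any difference.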